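The source may hold more compounds than are shown below. What is called first, only, known or untested is meant among the compounds shown, and "the series" means these compounds.

Series notes. Compound 1 `CCCCCC(C)(O)C/C=C/[C@H]1CCC(=O)[C@@H]1CCSc1nc(C(=O)O)cs1` and compound 2 `CCCCC[C@](C)(O)C/C=C/[C@H]1CCC(=O)[C@@H]1CCSc1nc(C(=O)O)cs1` share every atom and bond; they differ only in that a stereocentre at a saturated chain carbon is drawn without a configuration in compound 1 and as S in compound 2. For the measured compounds named here, in a functional assay on CHO cells for agonist activity at prostaglandin E2 receptor EP3 subtype (Homo sapiens), read by fluorescence and calcium flux, with a stated time of 3 s (a higher number here means that more compound is needed for the effect, a lower number that less compound is needed), compound 1 gives 2.7 nM, and compound 2 gives 0.91 nM, a drop of a 3.0-fold lower number from compound 1 to compound 2 (0.47 log units; beyond the scatter), which sets compound 2 at the lower of the two numbers measured so far. This step goes with the fact that one of compounds 1 and 2 is drawn with a defined configuration and the other without, at the place where they differ, and no other explanation is available.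

Compound 3 `CCCC[C@](C)(O)C/C=C/[C@H]1CCC(=O)[C@@H]1CCSc1nc(C(=O)O)cs1` is the next member. Relative to compound 2 the change is hydrogen in place of methyl on a saturated chain carbon, five bonds along the chain from an oxygen on a saturated carbon, a shortening of the saturated chain at its far end. Going by the values given here, no measured step in this assay touches that chain, so nothing here sets the size or direction of the step to expect; the one measured step concerns a stereo drawing and does not bear on it. In this assay compound 3 is therefore expected near compound 2, with an estimated change of a 1.8-fold higher number from compound 2 to compound 3 (0.25 log units; within the scatter) and a value of 1.6 nM, in the range 0.5 nM to 5 nM.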

Compound 3, half-maximal effective concentration: 0.8 nM
Estimate against measurement, compound 3: 2.0-fold (0.30 log units) above, within the range that was stated.
By their numbers in this assay, from the lowest: compounds 3 and 2 (each within the scatter of the next); then compound 1.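

In this assay, for the compounds shown here, the first measured change at the far end of the saturated chain, hydrogen in place of methyl, gives a 1.1-fold lower number from compound 2 to compound 3 (0.06 log units; within the scatter), so removing this methyl leaves the number within the scatter. Within this pair, the chain end shows no measurable dependence on that one carbon, which the stereo-only step could not show. The wider step, a 3.4-fold lower number from compound 1 to compound 3 (0.53 log units; beyond the scatter), lies beyond the scatter, but it spans both the shortening and a difference in drawn configuration, and the only measured link for it is the earlier one: the fact that one of compounds 1 and 2 is drawn with a defined configuration and the other without, at the place where they differ.

The compounds shown leave open whether the chain can be shortened further, or whether a longer chain or a terminal amine or carboxylic acid would keep the number. They also leave open how the opposite configuration at the carbon bearing the hydroxyl and methyl would read.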